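Ortho substituent on the phenoxy ring: fluoro to bromo

The compounds below may be only part of what the source reports. "The series", "measured", "known", "first", "only" and "open" are said of these compounds alone.

Measured so far:
compound 1, `CC(C)(Oc1ccccc1F)C1OCC(C/C=C\CCC(=O)O)C(c2cccnc2)O1`: in an assay for inhibition of prostacyclin synthase (Homo sapiens), using microsomes (a higher number here means a weaker inhibitor, a lower number a stronger inhibitor), compound 1 gives < 1000 nM, a limit of the assay.
compound 2, `CSc1ccccc1OC(C)(C)C1OCC(C/C=C\CCC(=O)O)C(c2cccnc2)O1`: in this assay compound 2 gives > 100000 nM, also a limit.

Compound 2 therefore stands at the weak end of the two values shown. Within the data shown here, the single measured step, an at least 100-fold higher number from compound 1 to compound 2 (2.00 log units; beyond the scatter), rests on two limits (the limit of < 1000 nM in this assay, at which 1 of the 2 values shown sits, (the limit of > 100000 nM in this assay, at which 1 of the 2 values shown sits)), and its true size is unknown. Compound 3, `CC(C)(Oc1ccccc1Br)C1OCC(C/C=C\CCC(=O)O)C(c2cccnc2)O1`, carries the change (bromo in place of methylsulfanyl on an aromatic carbon). Bromo, like fluoro, brings no hydrogen-bond acceptor and one heavy atom. A large step back in the direction of compound 1 is expected, of uncertain size. Compound 3 is estimated at 5000 nM (500 nM to 50000 nM), a step of an at least 20-fold lower number from compound 2 to compound 3 (1.30 log units; beyond the scatter).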

Compound 3, half-maximal inhibitory concentration: 7000 nM
Compound 3: the middle estimate sits 1.4-fold (0.15 log units) below what was measured; the range from low to high includes it.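

In this assay, among these compounds, compound 3 gives the first value at this position that is not a limit. Bromo in place of methylsulfanyl gives an at least 14-fold lower number from compound 2 to compound 3 (1.15 log units; beyond the scatter) and bromo in place of fluoro gives an at least 7.0-fold higher number from compound 1 to compound 3 (0.84 log units; beyond the scatter) so two groups without a hydrogen-bond acceptor do not match here. As far as these compounds go, each step has a limit at one end, and its true size stays unknown.

Where chloro, methoxy or a nitrile would fall at this position stays open. So does whether the sulfur or the methyl of methylsulfanyl goes with the weak result of compound 2.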